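This account rests on a few compounds, and the source may have more. Where it says the series, first, only, none or still open, it means among the compounds named here.

Compound 1, `CC(=O)Nc1ccn([C@@H]2CO[C@H](CO)O2)c(=O)n1`: 6870 nM
Compound 2, `CCCC(=O)Nc1ccn([C@@H]2CO[C@H](CO)O2)c(=O)n1`: 6600 nM
Compound 3, `CCCCCCCCCCCCCCCC(=O)Nc1ccn([C@@H]2CO[C@H](CO)O2)c(=O)n1`: 4 nM

All three were tested in a functional assay on A549 cells (Homo sapiens) for cytotoxicity, read by sulforhodamine B assay, with a stated time of 72 h; on this read-out higher numbers stand for weaker inhibition and lower numbers for stronger inhibition. Compound 2 differs from compound 1 by ethyl in place of hydrogen on a saturated chain carbon bound to a carbonyl carbon, and that change gave a 1.0-fold lower number from compound 1 to compound 2 (0.02 log units; within the scatter). Compound 3 carries a far longer chain on the shared core; how its structure differs from compound 1 is not broken down here. Compound 3 gives the lowest number of the three, and its gaps to compound 2 and to compound 1 both lie beyond the scatter.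

Compound 4, `CCCCCCCCCCCCCCCCCC(=O)Nc1ccn([C@@H]2CO[C@H](CO)O2)c(=O)n1`, is not yet measured. It differs from compound 3 by ethyl in place of hydrogen on a saturated chain carbon, ten or more bonds along the chain from a carbonyl carbon. This is the same kind of change as that from compound 1 to compound 2, but at a different place on the chain. A small step is expected, a 1.3-fold higher number from compound 3 to compound 4 (0.10 log units; within the scatter), because the earlier change of this kind gave a 1.0-fold lower number from compound 1 to compound 2 (0.02 log units; within the scatter) and compound 3 already gives 4 nM. Compound 4 is expected at 5 nM, estimated between 1.5 nM and 20 nM.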

Compound 4, half-maximal inhibitory concentration: 25 nM
For compound 4 the middle estimate is 5.0-fold (0.70 log units) below the measured one, and the stated range ends below it.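

In this assay the new step is a 6.3-fold higher number from compound 3 to compound 4 (0.80 log units; beyond the scatter), so on the long chain of compound 3, putting ethyl in place of hydrogen goes with weaker inhibition. Set beside the earlier step, the same change does not keep its size from one core to another, so the result on one compound could not be carried over to the other: the same change on two cores in this assay, a 1.0-fold lower number (0.02 log units; within the scatter) from compound 1 to compound 2 and a 6.3-fold higher number (0.80 log units; beyond the scatter) from compound 3 to compound 4, 6.5-fold (0.81 log units) apart, beyond the scatter of two such steps This shows only that the outcome of this change differed in these two pairs, where it also sits at different places along the chain; two pairs give no rule for the series and do not explain the difference.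

The compounds shown leave open how the numbers run for chains of intermediate length, and so where along the chain the large gap in inhibition opens. They also leave open whether a still longer chain, or a chain ending in an amine or a carboxylic acid, would continue the upward step seen with compound 4.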